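One Added Methyl Group, Measured and Expected

The source may report more compounds than this note shows. Statements on the series, on what has been measured and on what is new or still open speak of the compounds shown alone.

Of the compounds shown here, three have so far been tested in an ADME assay on PANC-1 cells (Homo sapiens) for inhibition, read by MTT assay; on this read-out higher numbers stand for weaker inhibition of growth and lower numbers for stronger inhibition of growth. Compound 1 `Cc1nc(C)c(-c2nn(-c3ccc(F)cc3)cc2/C=C/C(=O)c2cc(Cl)ccc2O)s1` gives only a limit of the assay, > 250 ug/mL. Compound 2 `Cc1nc(C)c(-c2nn(-c3ccc(F)cc3)cc2/C=C/C(=O)c2cc(Cl)c(C)cc2O)s1` likewise gives only a limit, > 250 ug/mL. The change between them is methyl in place of hydrogen on an aromatic carbon, and the step that the two limits leave unreadable from compound 1 to compound 2; both values sit at the limit of > 250 ug/mL in this assay, at which 2 of the 3 values shown sit. Compound 3 `Cc1nc(C)c(-c2nn(-c3ccc(F)cc3)cc2C2CC(c3cc(Cl)c(C)cc3O)=NN2)s1` carries a different core, and how its core differs from that of compound 1 is not broken down here. In this assay, going by the values given here, compound 3 gives 127 ug/mL, the only plain number among the three.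

Compound 4 `Cc1nc(C)c(-c2nn(-c3ccc(F)cc3)cc2C2CC(c3c(O)cc(C)c(Cl)c3C)=NN2)s1` has not yet been measured. It differs from compound 3 by methyl in place of hydrogen on an aromatic carbon. This is the same kind of change as from compound 1 to compound 2, though the surroundings differ: here the entering methyl is ortho to a large group and meta to a methyl group, whereas in compound 2 it is para to a large group. The expectation for compound 4 rests on compound 3 alone, since the step that the two limits leave unreadable from compound 1 to compound 2 offers no readable size. Compound 4 is expected to make the step of a 1.1-fold lower number from compound 3 to compound 4 (0.02 log units; within the scatter), a small one. Compound 4 is therefore estimated at 120 ug/mL, within a range from 50 ug/mL to 250 ug/mL.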

Compound 4, concentration for 50% growth inhibition: 41.6 ug/mL
Estimate against measurement, compound 4: 2.9-fold (0.46 log units) above, outside the stated range (below it).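

In this assay, methyl in place of hydrogen on the core of compound 3 gives a 3.1-fold lower number from compound 3 to compound 4 (0.48 log units; beyond the scatter), so on this core the change goes with stronger inhibition of growth. The same kind of change on the core of compound 1 cannot be read, as compound 1 and compound 2 each give only a limit of the assay: the limit of > 250 ug/mL in this assay, at which 2 of the 4 values shown sit. The series therefore shows a real step on one core, but not that the step carries over from one core to another, and the methyl does not enter at the same place in the two pairs, since in compound 4 it stands ortho to a chloro group and ortho to a large group.

The compounds shown leave open whether the step belongs to methyl itself, or whether an ethyl group, a methoxy group or an amine at the same place would go the same way. They also leave open how a methyl at this place would behave on the core of compound 1.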